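The source may hold more compounds than are shown below. What is called first, only, known or untested is meant among the compounds shown, and "the series" means these compounds.

Values so far in a functional assay on HL-60 cells (Homo sapiens) for antiproliferative activity, read by MTT assay; a higher number here means a weaker inhibitor, a lower number a stronger inhibitor
Compound 1 `O[C@@H]1[C@@H](OCc2ccccc2)[C@H](OCc2ccccc2)[C@@H](COCc2ccccc2)O[C@@H]1Cc1ccccc1`: "not active" (no number reported)
Compound 2 `O[C@@H]1[C@@H](OCc2ccccc2)[C@H](OCc2ccccc2)[C@@H](COCc2ccccc2)O[C@H]1Cc1ccccc1`: 8700 nM
Compound 3 `CC(=O)O[C@@H]1[C@@H](OCc2ccccc2)[C@H](OCc2ccccc2)[C@@H](COCc2ccccc2)O[C@@H]1Cc1ccccc1`: "not active" (no number reported)

Compound 1 sits at the inactive end of this small set, with no single number: this assay reports it only as "not active" (no number reported) and gives no figure to measure from. Compound 3 has the same outcome ("not active" (no number reported)). Given the fact that compounds 1 and 2 differ only in the configuration as drawn the measurable activity of compound 2 (8700 nM) points to configuration as what separates that pair.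

The next compound to be tested is compound 4 `C=C[C@H]1O[C@H](COCc2ccccc2)[C@@H](OCc2ccccc2)[C@H](OCc2ccccc2)[C@H]1O` and its change is vinyl in place of benzyl on a saturated ring carbon in the core of compound 1. In words, vinyl takes the place of benzyl on a saturated ring carbon, next to the ring oxygen and next to the ring atom that bears a hydroxy group.

For the measured compounds named here, no measured step covers this change, and compound 1 offers no number to count a step from. In this assay the expected move is therefore modest and in the direction of stronger inhibition, reaching roughly the level of compound 2 (8700 nM) or somewhat weaker. Compound 4 may just as well end up with no number at all. For compound 4 the estimated value is 15000 nM within an expected range from 5000 nM to 50000 nM (an estimate, not a measurement).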

Compound 4, half-maximal inhibitory concentration: "not active" (no number reported)
Nothing numeric was reported for compound 4; there is nothing to compare the estimate with.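

In this assay compound 1 gives "not active" (no number reported) and compound 4 gives "not active" (no number reported) so no step can be read between them. The compounds shown leave open whether vinyl in place of benzyl changes activity at all, and whether compound 4 would gain measurable activity with the configuration of compound 2. No available evidence bears on this result.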